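Compound 3 to compound 4: cyclopentyl replaced by hydrogen

The source may hold more compounds than are shown below. What is called first, only, known or untested is meant among the compounds shown, and "the series" means these compounds.

The series shares one core and varies the group on an aromatic nitrogen, read in a toxicity assay on THP-1 cells (Homo sapiens) for inhibition; a lower number here means that less compound is tolerated, a higher number that more compound is tolerated. Compound 1 `COc1ccc(-c2cnc(NC(=O)c3ccc(F)cc3)n2Cc2ccccc2)cc1`, with benzyl, gives > 100000 nM, which is a limit of the assay and not a number. Compound 3 `COc1ccc(-c2cnc(NC(=O)c3ccc(F)cc3)n2C2CCCC2)cc1`, with cyclopentyl, gives > 100000 nM, again a limit and not a number. Going by the values given here, compound 2 `COc1ccc(-c2cnc(NC(=O)c3ccc(F)cc3)n2-c2ccccc2)cc1`, with phenyl, gives 8800 nM, the only actual number so far. Compound 3 therefore stands at the limit of > 100000 nM in this assay, at which 2 of the 3 values shown sit.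

The next compound is compound 4 `COc1ccc(-c2cnc(NC(=O)c3ccc(F)cc3)[nH]2)cc1`, and the change is hydrogen in place of cyclopentyl on an aromatic nitrogen. In words, this is hydrogen in place of cyclopentyl on an aromatic nitrogen. Two measured steps at this nitrogen bear on it: an at least 11-fold lower number from compound 1 to compound 2 (1.05 log units; beyond the scatter) and an at least 11-fold higher number from compound 2 to compound 3 (1.05 log units; beyond the scatter), both large and beyond the scatter. A third, a step that the two limits leave unreadable from compound 1 to compound 3, cannot be read. Among these groups, only phenyl has brought the number down. Hydrogen is a different replacement, so a drop of that size is not expected, and a second reading at the limit is quite possible. The step expected is an at least 1.4-fold lower number from compound 3 to compound 4 (0.15 log units; that floor lies within the scatter). For compound 4 the estimated value is 70000 nM, with an expected range from 15000 nM to 100000 nM.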

Compound 4, half-maximal cytotoxic concentration: > 100000 nM
Compound 4 was reported as a limit; the forecaster's own chance of this, stated with the estimate: 55%; middle value at least 1.4-fold (0.15 log units) away from the limit.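

In this assay compound 4 gives > 100000 nM, a limit of the assay and not a number. Taking the group off the aromatic nitrogen altogether, with only hydrogen and no heavy atom left there, therefore does not bring the number down, and this reading joins those of the benzyl and cyclopentyl compounds. Set against phenyl, the change gives an at least 11-fold higher number from compound 2 to compound 4 (1.05 log units; beyond the scatter), while the steps from compound 1 and from compound 3 to compound 4 cannot be read, as both ends of each are limits, and compound 2 remains the only compound in the series with an actual number: the limit of > 100000 nM in this assay, at which 3 of the 4 values shown sit.

Going by these compounds, the numbers behind the three limits stay open, so no order can be given among compound 1, compound 3 and compound 4. Also open, on these data alone, is whether the lower number belongs to phenyl alone or also appears with other groups on this nitrogen, such as a pyridyl ring, a methyl group or a longer chain ending in an amine.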